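The source may hold more compounds than are shown below. What is called first, only, known or untested is meant among the compounds shown, and "the series" means these compounds.

For the measured compounds named here, in a functional assay on HepG2 cells (Homo sapiens) for inhibition, read by MTT assay, with a stated time of 24 h (a higher number here means a weaker inhibitor, a lower number a stronger inhibitor), three compounds with a shared core have numbers so far: compound 1 (`CC1(C)[C@H]2CC[C@]1(C)N(Cc1cn(-c3cccc(F)c3)nn1)C(=O)C2`) gives 80 nM, compound 2 (`CC1(C)[C@H]2CC[C@]1(C)N(Cc1cn(-c3ccccc3Br)nn1)C(=O)C2`) gives 150 nM and compound 3 (`CC1(C)[C@H]2CC[C@]1(C)N(Cc1cn(-c3cccc(C#N)c3)nn1)C(=O)C2`) gives 40 nM. Compound 3 thus stands within the scatter of compound 1 and clearly apart only from compound 2. Compound 4 (`CC1(C)[C@H]2CC[C@]1(C)N(Cc1cn(-c3cccc(Cl)c3)nn1)C(=O)C2`) has chloro in place of cyano on an aromatic carbon, meta to a large group: chloro in place of cyano on an aromatic carbon. The closest guide is the exchange of fluoro and cyano at that place, a 2.0-fold lower number from compound 1 to compound 3 (0.30 log units; within the scatter). The wider exchange, a 3.8-fold lower number from compound 2 to compound 3 (0.57 log units; beyond the scatter), also removes the 2-bromophenyl and says less here. The expected change is small, a 1.5-fold higher number from compound 3 to compound 4 (0.18 log units; within the scatter), towards a slightly higher number. Compound 4 is estimated at 60 nM, with an expected range of 28 nM to 130 nM.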

Compound 4, half-maximal inhibitory concentration: 60 nM
The estimate for compound 4 equals the measured number at the digits printed; the measured number falls inside the stated range.
By their numbers in this assay, from the lowest: compounds 3, 4, 1 and 2 (each within the scatter of the next, the first and the last beyond it).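

At this aromatic carbon, chloro now joins fluoro and cyano, and in this assay the two steps to it, a 1.5-fold higher number from compound 3 to compound 4 (0.18 log units; within the scatter) and a 1.3-fold lower number from compound 1 to compound 4 (0.12 log units; within the scatter), are both small, so these three groups cannot be told apart by their numbers. Exchanging the 2-bromophenyl for 3-chlorophenyl gives a 2.5-fold lower number from compound 2 to compound 4 (0.40 log units; beyond the scatter) and places a second compound clearly apart from compound 2. No measurement is at hand that explains these numbers. On these data alone, whether an amine or a carboxylic acid at this carbon would also leave the number close to these values remains open.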